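Changing the aryl group on the ring nitrogen of a thiazolidinone series

The compounds below may be only part of what the source reports. "The series", "measured", "known", "first", "only" and "open" are said of these compounds alone.

Measured compounds:
compound 1, `COc1ccc(C)cc1N1C(=O)CSC1c1cccc(C(=O)NCCCCc2ccccc2)c1`: 29%
compound 2, `COc1ccc(F)cc1N1C(=O)CSC1c1cccc(C(=O)NCCCCc2ccccc2)c1`: 62%
compound 3, `COc1cc(F)ccc1N1C(=O)CSC1c1cccc(C(=O)NCCCCc2ccccc2)c1`: 63%

In a functional assay on 143B cells (Homo sapiens) for inhibition, read by CCK-8 assay, with a stated time of 72 h, tested at 1 uM (a higher number here means more inhibition at the concentration tested (going by the name of the read-out), a lower number less inhibition), compound 1 gives the lowest of the three numbers; compound 2 and compound 3 both stand well above it. The step of a number 33 percentage points higher from compound 1 to compound 2 (beyond the scatter) and the step of a number 34 percentage points higher from compound 1 to compound 3 (beyond the scatter) are both large, while the step of a number 1 percentage points higher from compound 2 to compound 3 (within the scatter) is within the scatter, so the two fluorinated aryl groups cannot be told apart.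

Compound 4, `COc1cccc(OC)c1N1C(=O)CSC1c1cccc(C(=O)NCCCCc2ccccc2)c1`, is not yet measured. It differs from compound 1 in this way: 2,6-dimethoxyphenyl in place of 2-methoxy-5-methylphenyl on an amide-type nitrogen in a ring. The two steps from compound 1 bear on it insofar as both replace the 2-methoxy-5-methylphenyl group and both raise the number strongly. For the measured compounds named here, no measured step shows what a second methoxy group does, so the expected direction is upward but the size is uncertain. Compound 4 is therefore expected to lie at about 45%, between 20% and 70%, an expected step of a number 16 percentage points higher from compound 1 to compound 4 (beyond the scatter).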

Compound 4, a percentage reported as inhibition, at one concentration (the size of the read-out at that concentration, not a potency): 31%
Estimate against measurement, compound 4: 14 percentage points above; the measured number falls inside the stated range.
By their numbers in this assay, from the lowest: compounds 1 and 4 (each within the scatter of the next); then compounds 2 and 3 (each within the scatter of the next).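

In this assay, 2,6-dimethoxyphenyl in place of 2-methoxy-5-methylphenyl on the amide-type nitrogen gives a number 2 percentage points higher from compound 1 to compound 4 (within the scatter) and so shows no separation between these two groups. Set against the fluorinated aryl groups, the same nitrogen position gives a number 31 percentage points lower from compound 2 to compound 4 (beyond the scatter) and a number 32 percentage points lower from compound 3 to compound 4 (beyond the scatter), which shows that replacing the 2-methoxy-5-methylphenyl group does not by itself raise the number: among these four compounds, only the two fluorinated aryl groups stand higher. Nothing measured on these compounds accounts for this difference.

On these data alone, whether a chloro or trifluoromethyl group in place of the fluoro would keep the higher number remains open. So does the outcome with the methoxy group replaced by an amine or a carboxylic acid on the same aryl ring.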